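Selenium substituent swap in the cytotoxicity series

This account rests on a few compounds, and the source may have more. Where it says the series, first, only, none or still open, it means among the compounds named here.

Two compounds of the series have numbers in a functional assay on PC-3 cells (Homo sapiens) for cytotoxicity, read by MTT assay, with a stated time of 72 h; on this read-out higher numbers stand for weaker inhibition and lower numbers for stronger inhibition. Compound 1 `Cc1cccc(Nc2ccccc2C(C)C(=O)OCCC[Se]C#N)c1C` gives 33200 nM there. Compound 2 `CC1=C(CC(=O)OCCC[Se]C#N)c2cc(F)ccc2/C1=C\c1ccc([S+](C)[O-])cc1` gives 22300 nM in this assay, the lower of the two numbers; its gap to compound 1 lies within the scatter, so the two stand together rather than in an order.

Compound 3 `CC1=C(CC(=O)OCCC[Se]C(F)(F)F)c2cc(F)ccc2/C1=C\c1ccc([S+](C)[O-])cc1` differs from compound 2 in one place: trifluoromethyl in place of cyano on a selenium. Within the data shown here, no measured pair carries this change, so its size in this assay cannot be read from the data. Among the measured compounds shown here, with only two numbers available and no matched pair, the working expectation is a step no larger than the scatter, in no fixed direction. Compound 3 is therefore expected to give about 20000 nM in this assay, within a range from 8000 nM to 50000 nM. The step implied by this estimate, a 1.1-fold lower number from compound 2 to compound 3 (0.05 log units; within the scatter), is expected to sit within the scatter.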

Compound 3, half-maximal inhibitory concentration: 11600 nM
Compound 3: middle estimate off by 1.7-fold (0.24 log units), on the high side; low and high end bracket the measured number.
By their numbers in this assay, from the lowest: compounds 3, 2 and 1 (each within the scatter of the next, the first and the last beyond it).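

Among these compounds, compound 2 and compound 3 form the first matched pair of the series at this selenium, so the size of this change can now be read directly: in this assay, trifluoromethyl in place of cyano on a selenium gives a 1.9-fold lower number from compound 2 to compound 3 (0.28 log units; within the scatter). On the core of compound 2, the nitrile is therefore not required for a number of this size, and the two groups stand together on this read-out. No measurement available here bears on what lies behind this result.

The compounds shown leave open how a methyl group or a phenyl ring on the same selenium would read. They also leave open whether the same swap on the core of compound 1 would again stay within the scatter.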